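This account rests on a few compounds, and the source may have more. Where it says the series, first, only, none or still open, it means among the compounds named here.

In a physicochemical assay for solubility, in phosphate buffer, measured as kinetic solubility, at pH 7.4 (a higher number here means a more soluble compound, a lower number a less soluble compound), compound 1 `Cc1oc(-c2ccc(Cl)cc2)nc1CN1CCC(C(=O)NCCCN2C[C@H](C)C[C@H](C)C2)CC1` gives > 72 ug/mL, which is a limit of the assay. Compound 2 `COc1cccc(C)c1-c1nc(CN2CCC(C(=O)NCCCN3C[C@H](C)C[C@H](C)C3)CC2)c(C)o1` gives > 73 ug/mL, also a limit, and this is all that is known of its standing. Compound 3 `Cc1ccc(-c2nc(CN3CCC(C(=O)NCCCN4C[C@H](C)C[C@H](C)C4)CC3)c(C)o2)cc1C` differs from compound 2 by a single change: 3,4-dimethylphenyl in place of 2-methoxy-6-methylphenyl on an aromatic carbon. Among the compounds with values here, the one measured step that bears on it, a step that the two limits leave unreadable from compound 1 to compound 2, exchanged the group at the same place, and it offers no size to carry over. The estimated step, an at least 1.0-fold lower number from compound 2 to compound 3 (0.01 log units; that floor lies within the scatter), is therefore expected to stay within the scatter, with no direction favoured in this assay. Compound 3 is expected at 70 ug/mL, with an estimated range of 35 ug/mL to 90 ug/mL.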

Compound 3, solubility: > 71 ug/mL
Compound 3: a limit, no number (the forecaster's own chance of this, stated with the estimate: 70%); middle value at least 1.0-fold (0.00 log units) away from the limit.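

In this assay, within the data shown here, the values of compound 1, compound 2 and compound 3 are all limits of the assay, and no step among them can be read. As far as these compounds go, whether 4-chlorophenyl, 2-methoxy-6-methylphenyl and 3,4-dimethylphenyl differ at all in this assay stays open.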